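This account rests on a few compounds, and the source may have more. Where it says the series, first, only, none or still open, it means among the compounds named here.

Compound 1 `COc1ccc(F)cc1Nc1cc(NC(=O)Nc2c(Cl)cccc2Cl)ncn1` gives 31.3% in a functional assay on NCI-H226 cells (Homo sapiens) for inhibition, read by MTT assay, with a stated time of 48 h, tested at 10 uM (a lower number here means less inhibition, a higher number more inhibition at the concentration tested (going by the name of the read-out)), while compound 3 `O=C(Nc1cc(Nc2ccc(F)c(Cl)c2)ncn1)Nc1c(Cl)cccc1Cl` gives 47.3%; the step between them, a number 16 percentage points higher from compound 1 to compound 3 (beyond the scatter), comes from changing only the group on a nitrogen on an aromatic ring. Compound 2 `CCc1cccc(Nc2cc(NC(=O)Nc3cc(OC)cc(OC)c3)ncn2)c1` gives 36.7%, the second highest of the three numbers, within the scatter of compound 1 and beyond it below compound 3. Compound 4 `COc1cc(NC(=O)Nc2cc(Nc3ccc(C)c(C)c3)ncn2)cc(OC)c1` differs from compound 2 by 3,4-dimethylphenyl in place of 3-ethylphenyl on a nitrogen on an aromatic ring. Within the data shown here, only one measured step touches that nitrogen, and it was modest after a far larger exchange of groups; here the same atoms are merely rearranged, so the expected step is a number 1.3 percentage points higher from compound 2 to compound 4 (within the scatter), nothing beyond the scatter. Compound 4 is therefore estimated at 38%, between 25% and 52%.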

Compound 4, a percentage reported as inhibition, at one concentration (the size of the read-out at that concentration, not a potency): 45.3%
Beside the measured number, compound 4's estimate is 7.3 percentage points below it; low and high end bracket the measured number.
By their numbers in this assay, from the lowest: compounds 1, 2, 4 and 3 (each within the scatter of the next, the first and the last beyond it).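

Swapping 3-ethylphenyl for 3,4-dimethylphenyl on this nitrogen keeps the same atoms, and in this assay it gives a number 8.6 percentage points higher from compound 2 to compound 4 (within the scatter), so rearranging these carbon substituents does not clearly move the number. At this position, only the larger exchange from 5-fluoro-2-methoxyphenyl to 3-chloro-4-fluorophenyl has given a step beyond the scatter. No measurement offered here explains the size of either step.

As far as these compounds go, it remains open whether a morpholine or a carboxylic acid on this phenyl ring would shift the number clearly. The same swap might also behave differently with the other urea group found in compound 1 and compound 3.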